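The compounds below may be only part of what the source reports. "The series", "measured", "known", "first", "only" and "open" are said of these compounds alone.

Measured so far in a functional assay on the whole organism with Mus musculus as the target, in the maximal electroshock model, with a stated time of 0.5 h; a higher number here means that more compound is needed for the effect, a lower number that less compound is needed:
compound 1 `C/C(=N\NC(=O)Nc1ccc(Br)cc1)c1ccc(O)cc1` gives 300 mg/kg;
compound 2 `CCOc1ccc(NC(=O)N/N=C(\C)c2ccccc2O)cc1` gives 100 mg/kg.

Compound 2 has the lower of the two numbers, and the gap to compound 1 is wider than the usual scatter, so less of compound 2 is needed for the effect. The next compound, compound 3 `CCOc1ccc(NC(=O)N/N=C(\C)c2ccc(O)cc2)cc1`, has not yet been measured. It differs from compound 2 in one place: 4-hydroxyphenyl in place of 2-hydroxyphenyl on a carbon with a double bond to nitrogen. Compound 3 therefore shares its 4-hydroxyphenyl with compound 1, while keeping the rest of compound 2. Compound 1 also carries a bromo group where compound 3 carries an ethoxy group, so the two measured numbers cannot be pulled apart into the effect of either change alone. With only these two data points, a moderate rise from compound 2 is expected, roughly at the edge of the scatter, and not a large one. For compound 3 the estimated minimum effective dose is 200 mg/kg, with a range from 100 mg/kg to 300 mg/kg. This estimate means an expected step of a 2.0-fold higher number from compound 2 to compound 3 (0.30 log units; within the scatter).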

Compound 3, minimum effective dose: 100 mg/kg
Beside the measured number, compound 3's estimate is 2.0-fold (0.30 log units) above it; low and high end bracket the measured number.
By their numbers in this assay, from the lowest: compounds 2 and 3 (each within the scatter of the next); then compound 1.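

In this assay, putting 4-hydroxyphenyl in place of 2-hydroxyphenyl on a carbon with a double bond to nitrogen gives no change at the digits printed from compound 2 to compound 3 (within the scatter), so in this one pair the choice between these two hydroxyphenyl groups makes no visible difference to the dose needed. Ethoxy in place of bromo on an aromatic carbon, read on its own for the first time, gives a 3.0-fold lower number from compound 1 to compound 3 (0.48 log units; beyond the scatter), a modest step but one that clears the usual spread of repeat measurements, so this is the one change shown here that shifts the number. No measurement at hand explains either result.

As far as these compounds go, each reading rests on a single pair, so it remains open whether the same holds with other groups on the carbon with a double bond to nitrogen, such as a plain phenyl or a methoxyphenyl. From the compounds shown here alone, it is equally open how far the number would move on the aromatic carbon with a longer chain such as butoxy, or with an amine, in place of ethoxy.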